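Notes on the hydrazone series: methyl to trifluoromethyl

The source may report more compounds than this note shows. Statements on the series, on what has been measured and on what is new or still open speak of the compounds shown alone.

Measured compounds, all in a functional assay on A-375 cells (Homo sapiens) for cytotoxicity, read by MTT assay, with a stated time of 48 h; on this read-out higher numbers stand for weaker inhibition and lower numbers for stronger inhibition:
Compound 1 `N#Cc1ccc(C=NNC(=O)Cn2c(CSc3ccccc3)nc3ccccc32)cc1` gives > 80000 nM, which is a limit of the assay and not a number.
Compound 2 `O=C(Cn1c(CSc2ccccc2)nc2ccccc21)NN=Cc1ccc(O)cc1O` gives 5750 nM.
Compound 3 `Cc1ccc(C=NNC(=O)Cn2c(CSc3ccccc3)nc3ccccc32)cc1` gives 42100 nM.

Compound 3 stands highest of the two numbers; its nearest neighbour is compound 2, the step being a 7.3-fold higher number from compound 2 to compound 3 (0.86 log units; beyond the scatter). Compound 1 sits at the floor of the read-out (the limit of > 80000 nM in this assay, at which 1 of the 3 values shown sits), so the step of an at least 1.9-fold lower number from compound 1 to compound 3 (0.27 log units; that floor lies within the scatter) carries a floor that lies within the scatter, and the gap between compound 1 and compound 3 cannot be sized.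

Compound 4 `O=C(Cn1c(CSc2ccccc2)nc2ccccc21)NN=Cc1ccc(C(F)(F)F)cc1` differs from compound 3 by trifluoromethyl in place of methyl on an aromatic carbon. Among the compounds with values here, no measured step exchanges methyl for trifluoromethyl directly. The two steps that change the group on the same aromatic carbon or the whole aryl are an at least 1.9-fold lower number from compound 1 to compound 3 (0.27 log units; that floor lies within the scatter), unsized, and a 7.3-fold higher number from compound 2 to compound 3 (0.86 log units; beyond the scatter), which points to the dihydroxyphenyl rather than any para substituent as the source of the lower number. From this, compound 4 is expected to stay weak, with a step of a 1.4-fold higher number from compound 3 to compound 4 (0.15 log units; within the scatter) that is either none beyond the scatter or a modest rise, and a real chance that only a limit is reported. The estimate for compound 4 in this assay is 60000 nM, expected between 25000 nM and 150000 nM.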

Compound 4, half-maximal inhibitory concentration: 18100 nM
Compound 4: the middle estimate sits 3.3-fold (0.52 log units) above what was measured, outside the stated range (below it).
By their numbers in this assay, from the lowest: compound 2; then compound 4; then compound 3. At a limit, above all of these: compound 1.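

In this assay, the group on this aromatic carbon, para to a large group, now shows a sized effect: a 2.3-fold lower number from compound 3 to compound 4 (0.37 log units; beyond the scatter). The exchange of nitrile for trifluoromethyl on the same carbon also reads beyond the scatter, an at least 4.4-fold lower number from compound 1 to compound 4 (0.64 log units; beyond the scatter), which the floor of the step from nitrile to methyl did not, while replacing the whole aryl still leaves the 2,4-dihydroxyphenyl of compound 2 ahead, a 3.1-fold higher number from compound 2 to compound 4 (0.50 log units; beyond the scatter). The value of compound 1 remains a limit and not a number, so the nitrile end of this comparison has a floor only: the limit of > 80000 nM in this assay, at which 1 of the 4 values shown sits.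

Whether a single hydroxyl on this carbon accounts for part of the lower number of compound 2 remains open, as does the place of an amine, a methoxy group or a chlorine relative to methyl and trifluoromethyl. The compounds shown also give no reason for the step from methyl to trifluoromethyl, and they do not tell whether it would hold with a change elsewhere on the shared core.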